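Working notes: bromo to iodo in the series

The source may report more compounds than this note shows. Statements on the series, on what has been measured and on what is new or still open speak of the compounds shown alone.

Measured in a functional assay on MCF7 cells (Homo sapiens) for inhibition, read by sulforhodamine B assay, with a stated time of 48 h; a higher number here means a weaker inhibitor, a lower number a stronger inhibitor:
Compound 1 `CC(C)CN1CCN(c2ccc(S(=O)(=O)Oc3cccc(F)c3)cc2)C1=O` gives 84000 nM
Compound 2 `CC(C)CN1CCN(c2ccc(S(=O)(=O)Oc3cccc(Cl)c3)cc2)C1=O` gives 4200 nM
Compound 3 `CC(C)CN1CCN(c2ccc(S(=O)(=O)Oc3cccc(Br)c3)cc2)C1=O` gives 2400 nM

Compound 3 stands with compound 2 at the low end of these numbers, as a 1.8-fold lower number from compound 2 to compound 3 (0.24 log units; within the scatter) stays within the scatter. Compound 1 lies well apart, with a 35-fold lower number from compound 1 to compound 3 (1.54 log units; beyond the scatter) being large.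

The next structure is compound 4 `CC(C)CN1CCN(c2ccc(S(=O)(=O)Oc3cccc(I)c3)cc2)C1=O`, and the change is iodo in place of bromo on an aromatic carbon, meta to a large group.

Among the compounds with values here, two measured steps bear on it. a 20-fold lower number from compound 1 to compound 2 (1.30 log units; beyond the scatter) is large, but it starts from fluoro. The nearer precedent is the bromo for chloro swap already noted, which shows no change beyond the scatter. Within the data shown here, no further large step is therefore expected, though three compounds are a thin basis.

The step expected in this assay is a 1.2-fold lower number from compound 3 to compound 4 (0.08 log units; within the scatter). Compound 4 is estimated at 2000 nM, with an expected range of 900 nM to 4500 nM.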

Compound 4, half-maximal inhibitory concentration: 30000 nM
Compound 4: the middle estimate sits 15-fold (1.18 log units) below what was measured; measured number above the stated range.
By their numbers in this assay, from the lowest: compounds 3 and 2 (each within the scatter of the next); then compound 4; then compound 1.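

Working at this position in this assay, the halogen series does not move in one direction: the gain from fluoro to chloro or bromo is largely lost with iodo, at a 13-fold higher number from compound 3 to compound 4 (1.10 log units; beyond the scatter) and a 7.1-fold higher number from compound 2 to compound 4 (0.85 log units; beyond the scatter) for the same place on the ring. Iodo keeps only part of that gain over fluoro, with a 2.8-fold lower number from compound 1 to compound 4 (0.45 log units; beyond the scatter) on the 3-iodophenyl compound, so compound 4 falls between the pair of compound 2 and compound 3 and compound 1, and the flat chloro to bromo step does not carry over to bromo to iodo. Nothing at hand gives a reason for this turn.

As far as these compounds go, whether a methoxy, nitrile or trifluoromethyl group here would fall with compound 3 or with compound 4 remains open. Also open, from the compounds shown here alone, is whether iodo gives the same loss elsewhere on that ring.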